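A few compounds are considered here, and "the series" means these few. Any claim that something is new, unique, unknown or untested is made for them only; others in the source may bear on it.

For the measured compounds named here, compound 2 `CC1CCN(C2CCN(S(=O)(=O)c3ccc(Cl)c(C(F)(F)F)c3)CC2)CC1` holds the lowest of the two numbers known in a functional assay on DLD-1 cells (Homo sapiens) for antiproliferative activity, read by CellTiter-Glo, with a stated time of 72 h; a lower number here means a stronger inhibitor, a higher number a weaker inhibitor: compound 2 gives 17 nM, while compound 1 `CC1CCN(C2CCN(S(=O)(=O)c3cccnc3)CC2)CC1` gives 2400 nM, a gap well beyond the scatter. Going by the values given here, the two compounds differ in more than one place, so no single step links them. Compound 3 `CC1CCN(C2CCN(S(=O)(=O)c3ccc(Cl)c(Cl)c3)CC2)CC1` differs from compound 2 by chloro in place of trifluoromethyl on an aromatic carbon. With nothing measured for such a change, compound 3 is expected to show a step of a 1.5-fold higher number from compound 2 to compound 3 (0.17 log units; within the scatter), likely none beyond the scatter. Compound 3 is therefore estimated at 25 nM, within 8 nM to 80 nM.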

Compound 3, half-maximal inhibitory concentration: 2.9 nM
Estimate against measurement, compound 3: 8.6-fold (0.94 log units) above; the whole stated range lies above it.
By their numbers in this assay, from the lowest: compound 3; then compound 2; then compound 1.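

In this assay, chloro in place of trifluoromethyl, ortho to a chloro group, gives a 5.9-fold lower number from compound 2 to compound 3 (0.77 log units; beyond the scatter), so the single chlorine atom is not merely tolerated at this position but goes with a lower number beyond the scatter. Taken as a whole, 3,4-dichlorophenyl in place of pyridin-3-yl on the sulfonyl sulfur gives an 830-fold lower number from compound 1 to compound 3 (2.92 log units; beyond the scatter), the first readable step at that place on the shared core. No measurement given here accounts for either step. Still open, on these data alone, is how a bromo, methyl or nitrile would fare at this position. Also open, as far as these compounds go, is whether either chloro is needed at all.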